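A few compounds are considered here, and "the series" means these few. Any claim that something is new, unique, unknown or untested is made for them only; others in the source may bear on it.

- Compound 1 `COc1cc(NC(C)CCCNC(=O)NNC(=O)NCCCCCO)c2ncccc2c1`: > 100000 nM, a limit
- Compound 2 `CCOC(=O)NC(c1ccccc1)c1ccc(Cl)cc1`: > 100000 nM, a limit
- Compound 3 `O=C(NC(c1ccccc1)c1ccc(Cl)cc1)n1nnc2ccccc21`: 18000 nM

In a functional assay on NCI-H460 cells (Homo sapiens) for inhibition, read by MTT assay, with a stated time of 4 days (on this read-out higher numbers stand for weaker inhibition and lower numbers for stronger inhibition), compound 2 gives > 100000 nM, which is a limit and not a number. Compound 2 therefore stands at the limit of > 100000 nM in this assay, at which 2 of the 3 values shown sit.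

Compound 4 `NNC(=O)NC(c1ccccc1)c1ccc(Cl)cc1` differs from compound 2 by aminoamino in place of ethoxy on a carbonyl carbon, with aminoamino in place of ethoxy on a carbonyl carbon. Going by the values given here, no measured step covers this change. Among the compounds with values here, compound 3 gives 18000 nM in this assay, the only true number on the shared core, and this keeps a measurable result for compound 4 plausible.

The expected at least 1.6-fold lower number from compound 2 to compound 4 (0.22 log units; that floor lies within the scatter) is modest, toward stronger inhibition, and may stay hidden behind the limit. Compound 4 is estimated at 60000 nM, with an expected range of 20000 nM to 150000 nM.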

Compound 4, half-maximal inhibitory concentration: > 100000 nM
Compound 4: only a limit was reported (the forecaster's own chance of this, stated with the estimate: 55%); middle value at least 1.6-fold (0.22 log units) away from the limit.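

In this assay compound 4 gives > 100000 nM, a limit. With compound 2 also at a limit, the step between compound 2 and compound 4 cannot be read. On these data alone, whether aminoamino in place of ethoxy on a carbonyl carbon shifts inhibition at all remains open.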